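The source may hold more compounds than are shown below. What is called first, only, known or untested is meant among the compounds shown, and "the series" means these compounds.

The three measured compounds share one core and differ only in the aryl group attached to an aromatic nitrogen of the five-membered aromatic ring with 3 nitrogen. Compound 1 `CC1(C)[C@H]2CC[C@]1(C)N(Cc1cn(-c3cccc(C#N)c3)nn1)C(=O)C2` carries a 3-cyanophenyl there, and in a functional assay on A549 cells (Homo sapiens) for inhibition, read by MTT assay, with a stated time of 24 h (a higher number here means a weaker inhibitor, a lower number a stronger inhibitor), compound 1 gives 440 nM. Compound 2 `CC1(C)[C@H]2CC[C@]1(C)N(Cc1cn(-c3ccccc3F)nn1)C(=O)C2` carries a 2-fluorophenyl, and in this assay compound 2 gives 240 nM. Compound 3 `CC1(C)[C@H]2CC[C@]1(C)N(Cc1cn(-c3ccccc3O)nn1)C(=O)C2` carries a 2-hydroxyphenyl, and in this assay compound 3 gives 230 nM. Compound 1 has the highest of the three numbers, yet the step of a 1.8-fold lower number from compound 1 to compound 2 (0.26 log units; within the scatter) and the step of a 1.9-fold lower number from compound 1 to compound 3 (0.28 log units; within the scatter) both lie within the scatter, as does the step of a 1.0-fold lower number from compound 2 to compound 3 (0.02 log units; within the scatter), so on these data the three compounds cannot be told apart.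

Compound 4 `CC1(C)[C@H]2CC[C@]1(C)N(Cc1cn(-c3ccc(Cl)cc3)nn1)C(=O)C2` has not yet been measured. It differs from compound 1 as follows: 4-chlorophenyl in place of 3-cyanophenyl on an aromatic nitrogen. The two steps that bear on this change are the earlier aryl exchanges from compound 1, and neither of them moved the number beyond the scatter. Since every aryl exchange on that aromatic nitrogen seen so far has stayed within the scatter, no step beyond the scatter is expected in this assay for compound 4 either. The estimate for compound 4 in this assay is 350 nM, with a range from 150 nM to 900 nM, which amounts to an expected step of a 1.3-fold lower number from compound 1 to compound 4 (0.10 log units; within the scatter).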

Compound 4, half-maximal inhibitory concentration: 70 nM
For compound 4 the middle estimate is 5.0-fold (0.70 log units) above the measured one; measured number below the stated range.
By their numbers in this assay, from the lowest: compound 4; then compounds 3, 2 and 1 (each within the scatter of the next).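

In this assay, the aryl group on the aromatic nitrogen can move the number beyond the scatter after all: 4-chlorophenyl in place of 3-cyanophenyl gives (a 6.3-fold lower number from compound 1 to compound 4 (0.80 log units; beyond the scatter)), and the same group also stands apart from 2-hydroxyphenyl (a 3.3-fold lower number from compound 3 to compound 4 (0.52 log units; beyond the scatter)) and from 2-fluorophenyl (a 3.4-fold lower number from compound 2 to compound 4 (0.54 log units; beyond the scatter)). Compound 4 is therefore the most potent of the four in this assay, with its steps to all the others printed as beyond the scatter, whereas the three earlier compounds, all within the scatter of one another, gave no sign that this position could separate compounds at all. Nothing measured here accounts for why this one aryl group stands apart.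

The compounds shown leave open whether the step belongs to the chloro group itself or to where it sits on the phenyl ring, a question that a 2-chlorophenyl, a 3-chlorophenyl or a 4-cyanophenyl on the same nitrogen would help to settle. From the compounds shown here alone, it also remains open whether a 4-bromophenyl, a 4-methoxyphenyl or a 4-aminophenyl would match compound 4 or fall back among the other three.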